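Trifluoromethyl Replacing Ethyl on the Shared Core

This account rests on a few compounds, and the source may have more. Where it says the series, first, only, none or still open, it means among the compounds named here.

Of the compounds shown here, three built on one shared core have been measured in an assay on NIH3T3 cells for inhibition of Sonic hedgehog protein (Mus musculus), read by a luciferase reporter, with a stated time of 48 h; a higher number here means a weaker inhibitor, a lower number a stronger inhibitor. Compound 1 `Cc1cccc(C)c1NC(=O)c1ccc(Nc2ncc(C3CC3)c(-c3ccc(OC(F)(F)F)cc3)n2)cc1` gives 1.3 nM, compound 2 `Cc1cccc(C)c1NC(=O)c1ccc(Nc2ncc(F)c(-c3ccc(OC(F)(F)F)cc3)n2)cc1` gives 1.6 nM, and compound 3 `CCc1cnc(Nc2ccc(C(=O)Nc3c(C)cccc3C)cc2)nc1-c1ccc(OC(F)(F)F)cc1` gives 5.3 nM. Compound 3 thus stands at the highest number of the three: the steps of a 4.1-fold higher number from compound 1 to compound 3 (0.61 log units; beyond the scatter) and a 3.3-fold higher number from compound 2 to compound 3 (0.52 log units; beyond the scatter) are both beyond the scatter, while a 1.2-fold higher number from compound 1 to compound 2 (0.09 log units; within the scatter) is within it. Compound 4 `Cc1cccc(C)c1NC(=O)c1ccc(Nc2ncc(C(F)(F)F)c(-c3ccc(OC(F)(F)F)cc3)n2)cc1` is not yet measured; it differs from compound 3 by trifluoromethyl in place of ethyl on an aromatic carbon, at the same place where compound 1 carries cyclopropyl and compound 2 carries fluoro. The two steps that bear on this change both show that swapping ethyl for another small group at this position moved the number down, and trifluoromethyl is again a small group carrying fluorine. A step downward of modest size is therefore expected, though the data hold nothing that pins trifluoromethyl itself. For compound 4 the expected result in this assay is 3 nM, within 1 nM to 12 nM, which means an expected step of a 1.8-fold lower number from compound 3 to compound 4 (0.25 log units; within the scatter).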

Compound 4, half-maximal inhibitory concentration: 0.53 nM
Beside the measured number, compound 4's estimate is 5.7-fold (0.75 log units) above it; measured number outside the range, below it.
By their numbers in this assay, from the lowest: compound 4; then compounds 1 and 2 (each within the scatter of the next); then compound 3.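

Trifluoromethyl is the first group at this position to separate from cyclopropyl and fluoro in this assay, and not only from ethyl. Besides a 10-fold lower number from compound 3 to compound 4 (1.00 log units; beyond the scatter) there is a 3.0-fold lower number from compound 2 to compound 4 (0.48 log units; beyond the scatter) and a 2.5-fold lower number from compound 1 to compound 4 (0.39 log units; beyond the scatter), which makes compound 4 the most potent of the four. The position therefore still tells groups apart at the low end of these numbers, where compound 1 and compound 2 could not be separated from each other.

Nothing measured here explains why trifluoromethyl gives the lowest number of these four groups. From the compounds shown here alone, whether a nitrile, a methoxy group or a longer fluorinated chain such as pentafluoroethyl at this position would go lower still stays open, as does whether the gain holds when other parts of the shared core change.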